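Pyrazinyl in Place of Methyl on the Piperazine Nitrogen

This account rests on a few compounds, and the source may have more. Where it says the series, first, only, none or still open, it means among the compounds named here.

Compound 2 `CN1CCN(C(=S)SCc2ccc(C(=O)Nc3ccccc3N)cc2)CC1` gives 75.7% in a functional assay on HeLa cells (Homo sapiens) for antiproliferative activity, read by CCK-8 assay, with a stated time of 72 h, tested at 8 uM (on this read-out higher numbers stand for a stronger effect at the one concentration tested and lower numbers for a weaker effect), the highest of the two numbers measured. Compound 1 `Nc1ccccc1NC(=O)c1ccc(CSC(=S)N2CCN(c3ccc(Cl)cc3)CC2)cc1`, which carries a 4-chlorophenyl on the same ring nitrogen, gives 44.8% in this assay; the step of a number 30.9 percentage points higher from compound 1 to compound 2 (beyond the scatter) is large. Compound 3 `Nc1ccccc1NC(=O)c1ccc(CSC(=S)N2CCN(c3cnccn3)CC2)cc1` is not yet measured. It differs from compound 2 by pyrazin-2-yl in place of methyl on an amine nitrogen in a ring. Among the compounds with values here, the only step that bears on this is the one from compound 1 to compound 2, in which replacing an aromatic ring on that nitrogen by methyl raised the read-out strongly. Compound 3 moves back from methyl to a six-membered aromatic ring, though a different one from that of compound 1, so a drop of roughly that kind is expected, with wide uncertainty. For compound 3 the estimated step is a number 20.7 percentage points lower from compound 2 to compound 3 (beyond the scatter). Compound 3 is expected to give 55%, within a range from 35% to 75%.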

Compound 3, a percentage reported as inhibition, at one concentration (the size of the read-out at that concentration, not a potency): 76.9%
The estimate for compound 3 lay 21.9 percentage points below the measured number; measured number above the stated range.
By their numbers in this assay, from the lowest: compound 1; then compounds 2 and 3 (each within the scatter of the next).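

In this assay, the change from methyl to pyrazin-2-yl on the ring nitrogen gives a number 1.2 percentage points higher from compound 2 to compound 3 (within the scatter), so a six-membered aromatic ring at this place does not by itself lower the read-out. The change from 4-chlorophenyl to pyrazin-2-yl at the same place gives a number 32.1 percentage points higher from compound 1 to compound 3 (beyond the scatter), so among these compounds the low number goes with 4-chlorophenyl, not with every aromatic ring on this nitrogen. No measurement at hand explains why these two aromatic groups differ. 

From the compounds shown here alone, it remains open whether plain phenyl, which lacks the chlorine, would read like compound 3 or like compound 1, a comparison that would separate the effect of the chlorine from that of the ring carrying it. Also open, going by these compounds, is how a longer chain, such as benzyl, would behave on this nitrogen.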